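Halogen on the fused ring of the shared core

The compounds below may be only part of what the source reports. "The series", "measured", "known", "first", "only" and "open" are said of these compounds alone.

Compound 1 `NC(=O)[C@@H](c1ccccc1)N(C(=O)c1ccccc1)[C@@H]1CCc2ccccc21` in an assay on HEK293T cells for antagonist activity at transient receptor potential cation channel subfamily M member 8 (Homo sapiens), read by fluorescence and calcium flux, with a stated time of 60 min (a higher number here means a weaker inhibitor, a lower number a stronger inhibitor), gives 270 nM and stands highest of the two numbers in hand. Compound 2 `NC(=O)[C@@H](c1ccccc1)N(C(=O)c1ccccc1)[C@@H]1CCc2ccc(F)cc21` in this assay gives 90 nM; the step of a 3.0-fold lower number from compound 1 to compound 2 (0.48 log units; beyond the scatter) is the only one that bears here. Compound 3 `NC(=O)[C@@H](c1ccccc1)N(C(=O)c1ccccc1)[C@@H]1CCc2c(Cl)cccc21` differs from compound 1 by chloro in place of hydrogen on an aromatic carbon: a halogen again, but a different one at a different place on that ring, so the fluoro step carries over only loosely. A modest downward step is expected, a 1.5-fold lower number from compound 1 to compound 3 (0.18 log units; within the scatter), with wide uncertainty. Compound 3 in this assay is estimated at 180 nM, plausibly between 60 nM and 540 nM.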

Compound 3, half-maximal inhibitory concentration: 720 nM
Compound 3: middle estimate off by 4.0-fold (0.60 log units), on the low side; the whole stated range lies below it.
By their numbers in this assay, from the lowest: compound 2; then compound 1; then compound 3.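

Chloro in place of hydrogen at this place on the aromatic ring, ortho to a fused ring and meta to a fused ring, moves the number in this assay upward (a 2.7-fold higher number from compound 1 to compound 3 (0.43 log units; beyond the scatter)), opposite to the fluoro step (a 3.0-fold lower number from compound 1 to compound 2 (0.48 log units; beyond the scatter)). A halogen on this ring therefore does not lower the number as such, at least across these two changes. Nothing measured here accounts for the rise.

The halogen and its place change together, so their contributions cannot be separated. Open, going by these compounds, is how fluoro at the chloro's place, or a methoxy group or an amine there, would read.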